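Oxan-4-yl for cyclopropyl on the amine of the core

The source may hold more compounds than are shown below. What is called first, only, known or untested is meant among the compounds shown, and "the series" means these compounds.

Among the compounds with values here, compound 1 `CCn1c(NC2CC2)nc2ccsc2c1=O` holds the higher of the two numbers so far: in an assay on cells for inhibition of high affinity 3',5'-cyclic-AMP phosphodiesterase 7A (Homo sapiens), read by scintillation counting and cAMP accumulation, with a stated time of 30 min (on this read-out higher numbers stand for weaker inhibition and lower numbers for stronger inhibition), compound 1 gives 2600 nM. Within the data shown here, compound 2 `CCn1c(NC(C)C)nc2c(C3CCCN(C(C)=O)C3)csc2c1=O` gives 5.1 nM in this assay, but it differs from compound 1 in more than one place, so the two values show only a wide gap and no single step. Compound 3 `CCn1c(NC2CCOCC2)nc2ccsc2c1=O` carries oxan-4-yl in place of cyclopropyl on a nitrogen on an aromatic ring. Among the measured compounds shown here, with no one-place step among the measured pair to lean on, a modest move toward stronger inhibition is expected, a 2.6-fold lower number from compound 1 to compound 3 (0.41 log units; beyond the scatter). Compound 3 is estimated at 1000 nM in this assay, within 250 nM to 4000 nM.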

Compound 3, half-maximal inhibitory concentration: 430 nM
The estimate for compound 3 lay 2.3-fold (0.37 log units) above the measured number, within the range that was stated.
By their numbers in this assay, from the lowest: compound 2; then compound 3; then compound 1.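

Oxan-4-yl in place of cyclopropyl on a nitrogen on an aromatic ring gives a 6.0-fold lower number from compound 1 to compound 3 (0.78 log units; beyond the scatter) in this assay, the only one-place step in the series so far. On the shared core, this position therefore accepts the six-membered ring with its hetero atom and shows stronger inhibition with it. No available evidence bears on the reason for this step.

Whether ring size or the ring oxygen accounts for the step remains open; cyclohexyl or piperidin-4-yl on the same nitrogen would separate them. Going by these compounds, how oxan-4-yl combines with the other substituent of compound 2 also remains open.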